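Cytotoxicity of a pyrimidine series: adding a second methoxy

This account rests on a few compounds, and the source may have more. Where it says the series, first, only, none or still open, it means among the compounds named here.

Measured compounds:
compound 1 `COc1cc(OC)nc(Nc2ccc(Cl)c(OCC=C(C)C)c2)n1` gives 28000 nM
compound 2 `COc1ccnc(Nc2ccc(C#N)c(OCC=C(C)C)c2)n1` gives 230 nM
compound 3 `CNc1ccnc(Nc2ccc(C#N)c(OCC=C(C)C)c2)n1` gives 22 nM

The numbers come from an ADME assay on MT2 cells (Homo sapiens) for cytotoxicity; a lower number here means that less compound is tolerated, a higher number that more compound is tolerated. Among the three, compound 2 stands second highest; its nearest neighbour is compound 3, a step of a 10-fold lower number from compound 2 to compound 3 (1.02 log units; beyond the scatter) away, and its furthest is compound 1, whose value is far higher. Compound 4 `COc1cc(OC)nc(Nc2ccc(C#N)c(OCC=C(C)C)c2)n1` has not yet been measured. It differs from compound 2 by methoxy in place of hydrogen on an aromatic carbon.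

Within the data shown here, only one measured step bears on this change, and only loosely: the large step of a 10-fold lower number from compound 2 to compound 3 (1.02 log units; beyond the scatter) shows that swapping the group on that same aromatic ring can move this assay by a sizeable amount. Among the measured compounds shown here, no measured pair isolates the addition of a methoxy on a hydrogen-bearing carbon of that ring. Compound 1 shares the dimethoxy ring of compound 4 but carries a chloro group where compound 4 carries a nitrile, and compound 1 sits highest of all, which hints that the dimethoxy ring is compatible with a high number. The step from compound 2 to compound 4 is therefore expected to be upward, estimated at an 8.7-fold higher number from compound 2 to compound 4 (0.94 log units; beyond the scatter), with wide uncertainty. Compound 4 is expected to give about 2000 nM, in a range from 300 nM to 15000 nM.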

Compound 4, half-maximal cytotoxic concentration: 810 nM
For compound 4 the middle estimate is 2.5-fold (0.39 log units) above the measured one, and the stated range covers the measured number.
By their numbers in this assay, from the lowest: compound 3; then compound 2; then compound 4; then compound 1.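

In this assay, the change of methoxy in place of hydrogen on an aromatic carbon, next to the ring nitrogen, now has a measured pair of its own: the addition gives a 3.5-fold higher number from compound 2 to compound 4 (0.55 log units; beyond the scatter) and so raises the number modestly but beyond the scatter. With the second methoxy present on both compounds, cyano in place of chloro gives a 35-fold lower number from compound 1 to compound 4 (1.54 log units; beyond the scatter) and this large step runs the other way. The high number of compound 1 therefore cannot be credited to the second methoxy alone, since compound 4 carries that methoxy and still sits well below compound 1, while the nitrile-bearing compound 2 and compound 4 differ only modestly.

On these data alone, whether an amine or a longer chain such as ethoxy on that same carbon would move the number as methoxy does remains open, as does whether methoxy gives a similar step when chloro stands in place of the nitrile. Nothing measured alongside these numbers accounts for either step.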